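The source may report more compounds than this note shows. Statements on the series, on what has been measured and on what is new or still open speak of the compounds shown alone.

Compound 1 `Nc1nc(N)c2nc(Nc3ccccc3)ccc2n1`, compound 2 `Nc1nc(N)c2nc(Nc3ccc(O)cc3)ccc2n1` and compound 3 `Nc1nc(N)c2nc(Nc3ccc(F)c(F)c3)ccc2n1` share one core and differ only in the groups on the ring attached through the amine. In an ADME assay on isolated protein for inhibition of Dihydrofolate reductase (Homo sapiens), using NADPH (a lower number here means a stronger inhibitor, a higher number a weaker inhibitor), compound 1 gives 1530 nM, compound 2 gives 1580 nM and compound 3 gives 2250 nM. The three numbers cannot be told apart, since each gap between them lies within the scatter of this assay; compound 3 therefore stands together with the other two rather than apart from them. For the measured compounds named here, the only single change measured so far, a 1.0-fold higher number from compound 1 to compound 2 (0.01 log units; within the scatter), left the number where it was. Compound 4 `Nc1nc(N)c2nc(Nc3cc(F)c(F)c(F)c3)ccc2n1` differs from compound 3 by fluoro in place of hydrogen on an aromatic carbon. Going by the values given here, no measured step adds a fluoro group on its own, and compounds 1 and 3 together show only that two fluoro groups leave the number within the scatter. On this basis the step of a 1.1-fold higher number from compound 3 to compound 4 (0.03 log units; within the scatter) is expected to be no larger than the scatter. Compound 4 is estimated at 2400 nM, between 1200 nM and 4800 nM.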

Compound 4, half-maximal inhibitory concentration: 1810 nM
Estimate against measurement, compound 4: 1.3-fold (0.12 log units) above; measured number inside the range.
By their numbers in this assay, from the lowest: compounds 1, 2, 4 and 3 (each within the scatter of the next).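

In this assay, for the compounds shown here, the step of a 1.2-fold lower number from compound 3 to compound 4 (0.09 log units; within the scatter) is the first measured step that adds a single fluoro group on its own. It shows that a fluoro group can take the place of hydrogen on this aromatic carbon, ortho to a fluoro group and meta to a large group, and leave the number within the scatter. No measurement shown gives a reason for this result. On these data alone, whether a different group on this carbon, such as a methoxy group, an amine or a carboxylic acid, would also leave the number within the scatter remains open. Also open, as far as these compounds go, is whether any change on this ring can move the number beyond the scatter at all.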